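A few compounds are considered here, and "the series" means these few. Any claim that something is new, unique, unknown or untested is made for them only; others in the source may bear on it.

Of the compounds shown here, three have so far been tested in an assay on HeLa cells for displacement of a labelled ligand from adenosine receptor A3 (Homo sapiens), with a stated time of 180 min, tested at 1 uM; on this read-out lower numbers stand for less inhibition and higher numbers for more inhibition at the one concentration tested (going by the name of the read-out). Compound 1 `CC1=C(C(=O)OC(C)C)[C@@H](c2ccco2)N/C(=N/C#N)N1` gives 4%, compound 2 `CCOC(=O)C1=C(C)N/C(=N\C#N)NC1c1cccs1` gives 3%, and compound 3 `CC1=C(C(=O)OC(C)C)C(C2CCCC2)NC(=O)N1` gives 7%. Compound 2 shows the smallest of the three numbers, but both others lie within the usual scatter of it, so the three are effectively alike and none can be called weaker or stronger. Compound 4 `CCOC(=O)C1=C(C)N/C(=N\C#N)NC1c1ccoc1` has not been measured; it differs from compound 2 by furan-3-yl in place of thiophen-2-yl on a saturated ring carbon. Because compound 2 gives 3% and compound 1 gives 4%, both small numbers, the step in this assay is expected to be none beyond the scatter. Compound 4 is estimated at 4%, within a range from 0% to 12%. The expected step of a number 1 percentage points higher from compound 2 to compound 4 (within the scatter) is thus negligible.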

Compound 4, a percentage reported as inhibition, at one concentration (the size of the read-out at that concentration, not a potency): 14%
For compound 4 the middle estimate is 10 percentage points below the measured one; measured number outside the range, above it.
By their numbers in this assay, from the lowest: compounds 2, 1, 3 and 4 (each within the scatter of the next, the first and the last beyond it).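

In this assay putting furan-3-yl in place of thiophen-2-yl on the saturated ring carbon gives a number 11 percentage points higher from compound 2 to compound 4 (beyond the scatter) and so shows that this position responds to a swap between two rings with the same count of heavy atoms, donors and acceptors. The step is modest, and nothing measured here explains it. Going by these compounds, both the hetero atom and its place in the ring change together in this one step, so their shares stay open. Also open, on these data alone, is how a phenyl or a pyridine ring would read at this carbon.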